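Adding a hydroxyethyl carbamoyl to compound 3

The compounds below may be only part of what the source reports. "The series", "measured", "known", "first", "only" and "open" are said of these compounds alone.

Compound 3 `COc1cc(NC(C)CCCNC(=O)NN)c2ncccc2c1` gives > 250000 nM in a functional assay on L1210 cells (Mus musculus) for inhibition, read by MTT assay, with a stated time of 4 days (on this read-out higher numbers stand for weaker inhibition and lower numbers for stronger inhibition), which is a limit and not a number. Compound 4 `COc1cc(NC(C)CCCNC(=O)NNC(=O)NCCO)c2ncccc2c1` differs by (2-hydroxyethyl)carbamoyl in place of hydrogen on an amine nitrogen. The nearest measured relative is compound 1 `COc1cc(NC(C)CCCNC(=O)NNC(=O)NCCCCCO)c2ncccc2c1`, which carries 5-hydroxypentyl on the same carbamoyl. Compound 1 gives > 250000 nM in this assay, also a limit. The matching measured change is a step that the two limits leave unreadable from compound 1 to compound 3. Compound 2 `COc1cc(NC(C)CCCNC(=O)NNC(=O)Nc2ccc(Cl)c(C(F)(F)F)c2)c2ncccc2c1` gives 19000 nM. Among the compounds with values here, the only readable change is an at least 13-fold lower number from compound 1 to compound 2 (1.11 log units; beyond the scatter), and it needed 4-chloro-3-(trifluoromethyl)phenyl in place of 5-hydroxypentyl, which compound 4 lacks. The expected step is a number no higher from compound 3 to compound 4 (the limit leaves the size open), with no readable gain expected in this assay. Compound 4 is estimated at 250000 nM, within a range of 100000 nM to 400000 nM.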

Compound 4, half-maximal inhibitory concentration: > 250000 nM
Compound 4: only a limit was reported (the forecaster's own chance of this, stated with the estimate: 75%); the middle value lies on the limit itself.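

With the 2-hydroxyethyl carbamoyl, compound 4 stays at a limit in this assay, as do compound 1 and compound 3, so the steps among these three cannot be read: the limit of > 250000 nM in this assay, at which 3 of the 4 values shown sit.
On the amide-type nitrogen, 2-hydroxyethyl in place of 4-chloro-3-(trifluoromethyl)phenyl gives an at least 13-fold higher number from compound 2 to compound 4 (1.11 log units; beyond the scatter), and neither hydroxyalkyl chain shown gives a readable value.
Going by these compounds, it remains open whether an unsubstituted phenyl on that nitrogen also gives a number under the limit, or whether the chloro and trifluoromethyl substituents are both needed. An aminoalkyl chain there is equally untested in the compounds shown.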